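Moving a Trifluoromethyl Group Around the Phenyl Ring

This account rests on a few compounds, and the source may have more. Where it says the series, first, only, none or still open, it means among the compounds named here.

In a functional assay on K562 cells (Homo sapiens) for antiproliferative activity, with a stated time of 72 h (on this read-out higher numbers stand for weaker inhibition and lower numbers for stronger inhibition), compound 1 `OC[C@H]1O[C@@H](n2cnc3c(NCc4ccc(Cl)cc4Cl)ncnc32)[C@H](O)[C@@H]1O` gives 106000 nM. Compound 2 `OC[C@H]1O[C@@H](n2cnc3c(NCc4cccc(C(F)(F)F)c4)ncnc32)[C@H](O)[C@@H]1O` reaches only a limit of this assay, > 166000 nM, so its value is not a number. Among the measured compounds shown here, the one measured step, an at least 1.5-fold higher number from compound 1 to compound 2 (0.19 log units; that floor lies within the scatter), ends at that limit of > 166000 nM in this assay, at which 1 of the 2 values shown sits, and therefore has no firm size. For the measured compounds named here, compound 3 `OC[C@H]1O[C@@H](n2cnc3c(NCc4ccc(C(F)(F)F)cc4)ncnc32)[C@H](O)[C@@H]1O` differs from compound 2 by 4-(trifluoromethyl)phenyl in place of 3-(trifluoromethyl)phenyl on a saturated chain carbon bound to a nitrogen on an aromatic ring, a shift of position that no measured step mirrors. With no basis for movement in either direction, the expected step that the limit leaves unreadable from compound 2 to compound 3 is none beyond the scatter. Compound 3 is therefore estimated at 180000 nM, within 80000 nM to 400000 nM, and most likely again only a limit.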

Compound 3, half-maximal inhibitory concentration: > 166000 nM
Compound 3 gave a limit, no number (the forecaster's own chance of this, stated with the estimate: 70%); the middle value lies beyond the limit too.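

The 4-(trifluoromethyl)phenyl group, like the 3-(trifluoromethyl)phenyl group, yields no number in this assay, so this shift of position has no measurable size here, and the step between compound 2 and compound 3 cannot be read: the limit of > 166000 nM in this assay, at which 2 of the 3 values shown sit.

Against the 2,4-dichlorophenyl group, the change gives an at least 1.5-fold higher number from compound 1 to compound 3 (0.19 log units; that floor lies within the scatter), so compound 3 cannot yet be set apart from compound 1.

Still open, on these data alone, is how far compound 2 and compound 3 lie past their limits, and whether an amine or a carboxylic acid on this phenyl ring would give a lower number.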